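Swapping thiophen-2-yl for 4-chlorophenyl on a sulfonamide

The compounds below may be only part of what the source reports. "The series", "measured", "known", "first", "only" and "open" are said of these compounds alone.

Among the measured compounds shown here, compound 1 `O=S(=O)(Nc1ccc(-c2nc3ccccc3o2)cc1)c1cccs1` and compound 2 `CS(=O)(=O)Nc1ccc2oc(-c3ccccc3)nc2c1` are the two measured members of this small set, both checked for toxicity to cells in an ADME assay on HEK293 cells (Homo sapiens) for cytotoxicity, read by resazurin assay, with a stated time of 48 h; on this read-out lower numbers stand for higher toxicity in this test and higher numbers for lower toxicity in this test. In this assay compound 1 gives > 100000 nM, which is a limit of the test rather than a measured number. In this assay compound 2 likewise gives > 100000 nM, again a limit. For the measured compounds named here, compound 1 therefore stands at the ceiling of what the test can report, and so does the only other measured compound: the limit of > 100000 nM in this assay, at which 2 of the 2 values shown sit. Compound 3 `O=S(=O)(Nc1ccc(-c2nc3ccccc3o2)cc1)c1ccc(Cl)cc1` has not yet been measured. It differs from compound 1 in a single place (4-chlorophenyl in place of thiophen-2-yl on a sulfonyl sulfur). Going by the values given here, no step between two measured compounds exists in this set to show what such a swap does to the read-out, and the values shown reveal only that neither measured compound reached a toxic concentration within the tested window. The step expected from this change is a number no higher from compound 1 to compound 3 (the limit leaves the size open), none beyond the scatter, with the test most probably reporting a limit again. In this assay compound 3 is expected near 100000 nM, within 40000 nM to 300000 nM.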

Compound 3, half-maximal cytotoxic concentration: > 100000 nM
Compound 3: no number, only a limit; the forecaster's own chance of this, stated with the estimate: 80%; the middle value lies on the limit itself.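

In this assay, among the compounds shown here, compound 1 and compound 3 each give only a limit, not a number, so no step between them can be read: the limit of > 100000 nM in this assay, at which 3 of the 3 values shown sit. The compounds shown leave open whether 4-chlorophenyl in place of thiophen-2-yl on a sulfonyl sulfur changes toxicity to cells at all, and at what concentration any of them would become toxic.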